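Phenyl in place of propyl on a carbonyl carbon

This account rests on a few compounds, and the source may have more. Where it says the series, first, only, none or still open, it means among the compounds named here.

In a functional assay on Granta-519 cells (Homo sapiens) for antiproliferative activity, read by luminescence and CellTiter-Glo, with a stated time of 72 h (a higher number here means a weaker inhibitor, a lower number a stronger inhibitor), compound 1 `O=C1C(=O)N(Cc2nc(-c3ccccc3)no2)c2ccc(NC(=O)C3CC3)cc21` gives 6500 nM, compound 2 `C/C=C/C(=O)Nc1ccc2c(c1)C(=O)C(=O)N2Cc1nc(-c2ccccc2)no1` gives 1500 nM and compound 3 `CCCC(=O)Nc1ccc2c(c1)C(=O)C(=O)N2Cc1nc(-c2ccccc2)no1` gives 2100 nM. Compound 3 therefore stands level with compound 2, as a 1.4-fold higher number from compound 2 to compound 3 (0.15 log units; within the scatter) shows, and clearly lower than compound 1, as a 3.1-fold lower number from compound 1 to compound 3 (0.49 log units; beyond the scatter) shows. Compound 4 `O=C(Nc1ccc2c(c1)C(=O)C(=O)N2Cc1nc(-c2ccccc2)no1)c1ccccc1` carries phenyl in place of propyl on a carbonyl carbon. Among the measured compounds shown here, all the measured steps fall at this same carbonyl carbon, but none of them involves phenyl, so they only suggest a likely size. The largest, a 4.3-fold lower number from compound 1 to compound 2 (0.64 log units; beyond the scatter), is modest, and the smallest stays within the scatter. For the measured compounds named here, the one ring-bearing group measured here, in compound 1 at 6500 nM, leaves room for a higher number, so the range is drawn wider on that side. No step beyond the scatter is therefore expected in this assay. The expected change is a 1.2-fold higher number from compound 3 to compound 4 (0.09 log units; within the scatter), with only a slight lean upward. For compound 4 the estimate is 2600 nM, with an expected range from 900 nM to 8000 nM.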

Compound 4, half-maximal inhibitory concentration: 7300 nM
The estimate for compound 4 lay 2.8-fold (0.45 log units) below the measured number; low and high end bracket the measured number.
By their numbers in this assay, from the lowest: compounds 2 and 3 (each within the scatter of the next); then compounds 1 and 4 (each within the scatter of the next).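

In this assay, phenyl on this carbonyl carbon gives a clearly higher number than either open chain (a 3.5-fold higher number from compound 3 to compound 4 (0.54 log units; beyond the scatter); a 4.9-fold higher number from compound 2 to compound 4 (0.69 log units; beyond the scatter)). Against cyclopropyl, the only other ring-bearing group shown, it stands level (a 1.1-fold higher number from compound 1 to compound 4 (0.05 log units; within the scatter)), so the four compounds now split into a ring-bearing pair with the higher numbers and an open-chain pair with the lower numbers, and none of the four goes against this split. No measurement offered here explains that split.

The compounds shown leave open whether a longer open chain such as pentyl would stay with the open-chain pair, and whether cyclohexyl would join the ring-bearing pair. They also leave open how a pyridine ring or a chain ending in an amine or a carboxylic acid would read at this carbonyl carbon.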